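This account rests on a few compounds, and the source may have more. Where it says the series, first, only, none or still open, it means among the compounds named here.

Compound 1 `CC(C)(C)c1ncncc1-c1ccccc1`: 48%
Compound 2 `CC(=O)N(C(C)=O)c1ncc(-c2ccccc2)c(C(C)(C)C)n1`: 22%

In a functional assay on the whole organism for inhibition, with Rattus norvegicus as the target, with stated times of 1 h and 3.5 h, at a dose of 100 mg/kg by the oral route (on this read-out higher numbers stand for more inhibition at the one dose given (going by the name of the read-out) and lower numbers for less inhibition), compound 2 gives 22%, the lowest of the two numbers shown, while compound 1 gives 48%. Compound 3 `CC(C)(C)c1nc(NC(N)=O)ncc1-c1ccccc1` carries ureido in place of diacetylamino on an aromatic carbon. Within the data shown here, the only measured step that bears on this change is a number 26 percentage points lower from compound 1 to compound 2 (beyond the scatter), which introduced the very group now being replaced. Among the measured compounds shown here, no measured step exchanges diacetylamino for ureido, so the direction is open; a modest move is expected, a number 13 percentage points higher from compound 2 to compound 3 (beyond the scatter). Compound 3 is therefore estimated at 35%, within a range from 10% to 60%.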

Compound 3, a percentage reported as inhibition, in the whole organism at one dose (the size of the read-out at that dose, not a potency): 14%
Compound 3: middle estimate off by 21 percentage points, on the high side; measured number inside the range.
By their numbers in this assay, from the lowest: compounds 3 and 2 (each within the scatter of the next); then compound 1.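

In this assay, ureido in place of diacetylamino gives a number 8 percentage points lower from compound 2 to compound 3 (within the scatter) and so does not separate these two groups at this position, although they differ in size and in hydrogen-bond donors. Set against hydrogen at the same aromatic carbon, ureido gives a number 34 percentage points lower from compound 1 to compound 3 (beyond the scatter) and is thus a second group that reads apart from compound 1. No evidence on the reason for this result is available. The compounds shown leave open how a free amine or a single acetylamino group at this position would read in this assay and whether any group here could match hydrogen.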